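Benzothiazole Replaces Dimethylcarbamoyl: Cytotoxicity Expected to Stay Low

This account rests on a few compounds, and the source may have more. Where it says the series, first, only, none or still open, it means among the compounds named here.

Compound 1 `Cc1ccccc1-c1cc(NCc2cncn2Cc2ccc(-c3ccccc3)cc2)ccc1-c1nc2ccccc2s1`: > 1000 nM, a limit of the assay
Compound 2 `c1ccc(-c2ccc(Cn3cncc3CNc3ccc(-c4cncs4)c(-c4ccccc4)c3)cc2)cc1`: > 1000 nM, a limit of the assay
Compound 3 `CN(C)C(=O)c1ccc(NCc2cncn2Cc2ccc(-c3ccccc3)cc2)cc1-c1ccccc1`: > 1000 nM, a limit of the assay

All three values come from a toxicity assay on NIH3T3 cells (Mus musculus) for cytotoxicity, read by resazurin assay; on this read-out higher numbers stand for an effect only at larger amounts of compound and lower numbers for an effect already at smaller amounts. Compound 3 sits at the limit, a reading the assay cannot resolve any further. Among the measured compounds shown here, the same is true of compound 1, and of compound 2, so no compound stands apart from another; the limit of > 1000 nM in this assay, at which 3 of the 3 values shown sit, covers every value shown. For the measured compounds named here, the only measured change in one place, a step that the two limits leave unreadable from compound 2 to compound 3, has both of its ends at the limit, so its size cannot be read. Compound 4 `c1ccc(-c2ccc(Cn3cncc3CNc3ccc(-c4nc5ccccc5s4)c(-c4ccccc4)c3)cc2)cc1` differs from compound 3 by 1,3-benzothiazol-2-yl in place of dimethylcarbamoyl on an aromatic carbon. Compound 1 already carries the 1,3-benzothiazol-2-yl group on the same core. Its value is a limit. Going by the values given here, no measured step gives a size or a direction for this change, so no shift beyond the scatter is expected, and the expected step that the limit leaves unreadable from compound 3 to compound 4 is small. For compound 4 the estimated value is 3000 nM, with an expected range from 1000 nM to 10000 nM, most likely reported again only as a limit.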

Compound 4, half-maximal effective concentration: > 1000 nM
Compound 4 was reported as a limit; the forecaster's own chance of this, stated with the estimate: 80%; the middle value does not contradict the limit.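

Compound 4 gives > 1000 nM, which is a limit of the assay. Among the compounds shown here, no step from compound 1, compound 2 or compound 3 to compound 4 can be read: the limit of > 1000 nM in this assay, at which 4 of the 4 values shown sit. The compounds shown leave open at what concentration any of the four would affect these cells, and whether exchanging these groups changes that.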